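The source may report more compounds than this note shows. Statements on the series, on what has been measured and on what is new or still open speak of the compounds shown alone.

Compound 1, `Sc1nnc(-c2ccc3c(c2)OCCO3)n1-c1ccccc1`: in a functional assay on HepG2 cells (Homo sapiens) for antiproliferative activity, read by MTT assay, with a stated time of 24 h (on this read-out higher numbers stand for weaker inhibition and lower numbers for stronger inhibition), compound 1 gives 60000 nM.
Compound 2, `O=[N+]([O-])c1ccccc1CSc1nnc(-c2ccc3c(c2)OCCO3)n1-c1ccccc1`: compound 2 gives 12000 nM.
Compound 3, `COc1cccc(CSc2nnc(-c3ccc4c(c3)OCCO4)n2-c2ccccc2)c1`: compound 3 gives 35100 nM.

Among these three numbers compound 3 stands second highest. Its nearest neighbour is compound 1, with a 1.7-fold lower number from compound 1 to compound 3 (0.23 log units; within the scatter), a gap within the scatter; its furthest is compound 2, with a 2.9-fold higher number from compound 2 to compound 3 (0.47 log units; beyond the scatter).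

Compound 4, `Fc1ccc(CSc2nnc(-c3ccc4c(c3)OCCO4)n2-c2ccccc2)c(F)c1`, is not yet measured. It differs from compound 3 in one place: 2,4-difluorophenyl in place of 3-methoxyphenyl on a saturated chain carbon bound to a sulfur.

For the measured compounds named here, no measured step exchanges one benzyl group for another of this kind. The only comparison between two benzyl groups on the sulfur is a 2.9-fold higher number from compound 2 to compound 3 (0.47 log units; beyond the scatter), and the whole spread of the three compounds, shown by a 5.0-fold lower number from compound 1 to compound 2 (0.70 log units; beyond the scatter) and a 1.7-fold lower number from compound 1 to compound 3 (0.23 log units; within the scatter), is modest. A step of at most modest size is therefore expected in this assay, with no firm direction. Compound 4 is expected to give about 22000 nM, within 7000 nM to 60000 nM. This amounts to an expected 1.6-fold lower number from compound 3 to compound 4 (0.20 log units; within the scatter).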

Compound 4, half-maximal inhibitory concentration: 1960 nM
Estimate against measurement, compound 4: 11-fold (1.05 log units) above; measured number outside the range, below it.
By their numbers in this assay, from the lowest: compound 4; then compound 2; then compounds 3 and 1 (each within the scatter of the next).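

In this assay, changing only the substituent on the benzyl ring attached to the sulfur can produce a large effect: an 18-fold lower number from compound 3 to compound 4 (1.25 log units; beyond the scatter). That step is far larger than the earlier exchange between two benzyl groups, a 2.9-fold higher number from compound 2 to compound 3 (0.47 log units; beyond the scatter), so this position is more sensitive than compounds 1 to 3 suggested. Compound 4 also has the lowest number of the four, with a 6.1-fold lower number from compound 2 to compound 4 (0.79 log units; beyond the scatter) and a 31-fold lower number from compound 1 to compound 4 (1.49 log units; beyond the scatter), so the 2,4-difluorobenzyl group goes well beyond what the 2-nitrobenzyl group achieved on the same sulfur.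

Nothing presented here explains why this group gives so much lower a number. The compounds shown also leave open whether both fluorines are needed, as a benzyl group carrying one fluorine or an unsubstituted benzyl group would show, and how a longer chain between the sulfur and the ring would compare.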